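The source may hold more compounds than are shown below. What is called first, only, known or untested is meant among the compounds shown, and "the series" means these compounds.

Compound 1 `COc1ccc(-c2cc(N)c(C(=O)c3cc(OC)c(OC)c(OC)c3)s2)cc1OC` gives 20 nM in a functional assay on CCRF-CEM cells (Homo sapiens) for antiproliferative activity; a lower number here means a stronger inhibitor, a higher number a weaker inhibitor; among the three numbers measured it is the second highest. Compound 2 `COc1cc(C(=O)c2sc(-c3ccccc3)cc2N)cc(OC)c1OC` gives 4.5 nM and compound 3 `COc1cc(C(=O)c2sc(-c3ccncc3)cc2N)cc(OC)c1OC` gives 110 nM. The change to compound 4 `COc1cc(C(=O)c2sc(-c3ccsc3)cc2N)cc(OC)c1OC` is thiophen-3-yl in place of 3,4-dimethoxyphenyl on an aromatic carbon. For the measured compounds named here, two measured steps bear on it: a 4.4-fold lower number from compound 1 to compound 2 (0.65 log units; beyond the scatter), where the smaller ring lowered the number, and a 5.5-fold higher number from compound 1 to compound 3 (0.74 log units; beyond the scatter), where a ring bearing a nitrogen raised it. Going by the values given here, the entering group is a small aromatic ring with one sulfur, and no sulfur-containing analogue has been measured, so the step is expected to fall between those two, most likely within the scatter or slightly lower. Compound 4 is therefore estimated at 12 nM in this assay, range 4 nM to 40 nM, a step of a 1.7-fold lower number from compound 1 to compound 4 (0.22 log units; within the scatter).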

Compound 4, half-maximal inhibitory concentration: 9.6 nM
Estimate against measurement, compound 4: 1.3-fold (0.10 log units) above; the measured number falls inside the stated range.
By their numbers in this assay, from the lowest: compound 2; then compound 4; then compound 1; then compound 3.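

In this assay, a sulfur-containing five-membered aromatic ring on the carbon next to the ring sulfur gives a 2.1-fold lower number from compound 1 to compound 4 (0.32 log units; beyond the scatter) and an 11-fold lower number from compound 3 to compound 4 (1.06 log units; beyond the scatter), so the small ring without nitrogen stays on the low side of the series. Thiophen-3-yl does not match phenyl, however, with a 2.1-fold higher number from compound 2 to compound 4 (0.33 log units; beyond the scatter), which leaves compound 2 lowest of the four. No measurement shown accounts for these differences.

Open, from the compounds shown here alone, is how thiophen-2-yl, furan-3-yl or a phenyl bearing a single methoxy group would compare with phenyl at this position.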